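The compounds below may be only part of what the source reports. "The series", "measured", "known", "first", "only" and "open" are said of these compounds alone.

Compound 1 `CCCCc1oc2ccccc2c1C(=O)c1ccc(OCC(=O)N2CCCCC2)cc1` gives 37100 nM
Compound 2 `CCCCc1oc2ccccc2c1C(=O)c1ccc(OCC(=O)N2CCOCC2)cc1` gives 45400 nM

In a functional assay on U-937 cells (Homo sapiens) for antiproliferative activity, read by MTT assay, with a stated time of 24 h (a higher number here means a weaker inhibitor, a lower number a stronger inhibitor), compound 2 gives 45400 nM, level with compound 1 within the scatter. Compound 3 `CCCCc1oc2ccccc2c1C(=O)c1ccc(OCC(=O)Nc2cccc(OC)c2)cc1` has (3-methoxyphenyl)amino in place of morpholin-4-yl on a carbonyl carbon. Among the compounds with values here, only one measured step bears on this site: a 1.2-fold higher number from compound 1 to compound 2 (0.09 log units; within the scatter). That step offers a weak guide, since neither compound 1 nor compound 2 carries an aromatic ring or a hydrogen-bond donor in this group. No step beyond the scatter is therefore expected, in either direction. The expected step is a 1.4-fold lower number from compound 2 to compound 3 (0.15 log units; within the scatter). For compound 3 the estimated value is 32000 nM, with an expected range from 10000 nM to 80000 nM.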

Compound 3, half-maximal inhibitory concentration: 24200 nM
Compound 3: the middle estimate sits 1.3-fold (0.12 log units) above what was measured, within the range that was stated.
By their numbers in this assay, from the lowest: compounds 3, 1 and 2 (each within the scatter of the next).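

In this assay, replacing either saturated ring on the carbonyl carbon with (3-methoxyphenyl)amino, which brings an aromatic ring and a hydrogen-bond donor, gives a 1.9-fold lower number from compound 2 to compound 3 (0.27 log units; within the scatter) and a 1.5-fold lower number from compound 1 to compound 3 (0.19 log units; within the scatter). This position therefore tolerates quite different groups in these three compounds, which all stay level with one another. Nothing measured here explains these small differences. Still open, from the compounds shown here alone, is how plain phenylamino or benzylamino would read on this carbonyl carbon, and whether any group placed there can produce a step beyond the scatter.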